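A few compounds are considered here, and "the series" means these few. Any claim that something is new, unique, unknown or untested is made for them only; others in the source may bear on it.

Working notes on the series, all read in a functional assay on HCT-116 cells (Homo sapiens), read by MTT assay, with a stated time of 72 h; on this read-out lower numbers stand for stronger inhibition and higher numbers for weaker inhibition. Compound 3 (`Nc1nc2c(c(-c3cccs3)cn2[C@@H]2O[C@H](CO)[C@@H](O)[C@H]2O)c(=O)[nH]1`) gives 19800 nM. Compound 2 (`Nc1nc(N)c2c(-c3cc4ccccc4o3)cn([C@@H]3O[C@H](CO)[C@@H](O)[C@H]3O)c2n1`) gives 14000 nM, which lies within the usual scatter of compound 3. Compound 1 (`Cc1ncnc2c1c(-c1ccoc1)cn2[C@@H]1O[C@H](CO)[C@@H](O)[C@H]1O`) reads > 20000 nM, which is a limit of the assay and not a number. Among the measured compounds shown here, compound 3 therefore has only one numerical neighbour, and that gap cannot be read as a difference.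

Compound 4 (`Nc1nc2c(c(-c3cc4ccccc4o3)cn2[C@@H]2O[C@H](CO)[C@@H](O)[C@H]2O)c(=O)[nH]1`) carries 1-benzofuran-2-yl in place of thiophen-2-yl on an aromatic carbon of the five-membered aromatic ring with 1 nitrogen: 1-benzofuran-2-yl in place of thiophen-2-yl on an aromatic carbon. For the measured compounds named here, no measured pair differs in this one place, so the size of the step has no direct precedent. Going by the values given here, the only guide is compound 2, which bears the same 1-benzofuran-2-yl on a different core and gives 14000 nM. On that basis, a small shift towards lower numbers is expected, not clearly beyond the scatter: a 1.5-fold lower number from compound 3 to compound 4 (0.18 log units; within the scatter). A reading that reaches the limit of the assay remains possible. For compound 4 the estimated value is 13000 nM, with an expected range of 5000 nM to 24000 nM.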

Compound 4, half-maximal inhibitory concentration: > 100000 nM
Compound 4 ended at the assay's limit; the forecaster's own chance of this, stated with the estimate: 30%; middle value at least 7.6-fold (0.88 log units) away from the limit.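

In this assay, 1-benzofuran-2-yl in place of thiophen-2-yl on an aromatic carbon of the shared core gives an at least 5.0-fold higher number from compound 3 to compound 4 (0.70 log units; beyond the scatter). Among the compounds shown here, this is the first one-place step, and it shows that the read-out at this position responds to the group carried there: adding a six-membered aromatic ring of carbon only to the five-membered aromatic ring takes the core of compound 3 from a measured number to the top of the reading. Compound 4 reads > 100000 nM, which is a limit and not a number, so the full size of the step stays unknown, and this reading stands alone at its limit: the limit of > 100000 nM in this assay, at which 1 of the 4 values shown sits.

For the compounds shown here, the change adds the six-membered ring and also puts oxygen in place of sulfur, so the single step cannot say which of the two carries the loss; furan-2-yl or 1-benzothiophen-2-yl on the same carbon would separate them. Also open, going by these compounds, is how this position on the same core responds to a smaller group such as methyl or to an aminomethyl chain.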